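Swapping fluoro for hydroxy on a weak HepG2 series

The source may report more compounds than this note shows. Statements on the series, on what has been measured and on what is new or still open speak of the compounds shown alone.

Compounds measured so far:
- compound 1 `C#CCSc1nc(Nc2ccc(F)cc2)c2ccncc2n1`: 10800 nM
- compound 2 `C#CCSc1nc(Nc2cc(OC)c(OC)c(OC)c2)c2ccncc2n1`: 14200 nM

In a functional assay on HepG2 cells (Homo sapiens) for inhibition, read by MTT assay, with a stated time of 72 h (on this read-out lower numbers stand for stronger inhibition and higher numbers for weaker inhibition), compound 1 gives 10800 nM, the lowest of the two numbers recorded, while compound 2 gives 14200 nM; the gap between the two lies within the scatter, so neither can be called stronger or weaker than the other. Both are weak inhibitors on this read-out. The unmeasured compound 3 `C#CCSc1nc(Nc2ccc(O)cc2)c2ccncc2n1` keeps the shared core of compound 1 and changes only one substituent: hydroxy in place of fluoro on an aromatic carbon. Among the compounds with values here, no step between measured compounds involves this change, so there is nothing to lean on except the two weak values already in hand. The expectation is a step from compound 1 to compound 3 of a 1.1-fold higher number from compound 1 to compound 3 (0.05 log units; within the scatter), that is, none beyond the scatter in either direction. Compound 3 is estimated at 12000 nM, with a range from 5000 nM to 30000 nM.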

Compound 3, half-maximal inhibitory concentration: > 80000 nM
Compound 3: no number, only a limit (the forecaster's own chance of this, stated with the estimate: 10%); at least 6.6-fold (0.82 log units) between middle value and limit.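

In this assay, hydroxy in place of fluoro on an aromatic carbon, para to a large group, gives an at least 7.4-fold higher number from compound 1 to compound 3 (0.86 log units; beyond the scatter). Within the data shown here, this is the first sign that this position responds to a change of a single atom, as the earlier compounds offered no step between them that could show it. Compound 3 gives > 80000 nM, which is a limit of the assay and not a number, so the step has a known minimum but no known full size: the limit of > 80000 nM in this assay, at which 1 of the 3 values shown sits.

The compounds shown leave open whether other groups at this position, such as an amine or a chloro group, would give values like that of compound 1 or a limit like that of compound 3. They also leave open whether this swap would have a similar outcome on a different core.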